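Sulfonyl in place of sulfamoylamino on the amide side-chain

The source may report more compounds than this note shows. Statements on the series, on what has been measured and on what is new or still open speak of the compounds shown alone.

Among the compounds with values here, compound 3 `CC[C@H]1CN(c2nc(N)c(C(=O)NCCNS(N)(=O)=O)nc2Cl)CCN1C1CCN(Cc2ccc(Cl)cc2)CC1` gives 1.9 nM in an in vitro assay on BaF3 cells for displacement of a labelled ligand from C-X-C chemokine receptor type 3 (Homo sapiens) (on this read-out lower numbers stand for stronger inhibition and higher numbers for weaker inhibition), which places it second highest of the three numbers measured so far. Compound 1 `CC[C@H]1CN(c2nc(N)c(C(=O)NCC(C)O)nc2Cl)CCN1C1CCN(Cc2ccc(Cl)cc2)CC1` gives 0.3 nM, and compound 2 `CC[C@H]1CN(c2nc(N)c(C(=O)NCC(C)(C)O)nc2Cl)CCN1C1CCN(Cc2ccc(Cl)cc2)CC1` gives 8.4 nM. The steps onto compound 3 are a 6.3-fold higher number from compound 1 to compound 3 (0.80 log units; beyond the scatter) and a 4.4-fold lower number from compound 2 to compound 3 (0.65 log units; beyond the scatter); the step between the two hydroxy-bearing analogues is a 28-fold higher number from compound 1 to compound 2 (1.45 log units; beyond the scatter).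

Compound 4 `CC[C@H]1CN(c2nc(N)c(C(=O)NCCS(C)(=O)=O)nc2Cl)CCN1C1CCN(Cc2ccc(Cl)cc2)CC1` differs from compound 3 by methylsulfonyl in place of sulfamoylamino on a saturated chain carbon, two bonds along the chain from an amide-type nitrogen. Within the data shown here, no measured step makes this change: all three steps so far alter the group attached to the amide-type nitrogen, and compound 3 is the only one bearing a sulfur-containing group. The measured steps show that variation of the side-chain moves this assay by modest to large amounts, so a change at the same location is not expected to be silent, yet they give no direction for the present exchange. A modest weakening is taken as the working expectation, with a wide range around it.

Compound 4 is therefore estimated at 4 nM in this assay, spanning 1 nM to 15 nM, so that the expected step is a 2.1-fold higher number from compound 3 to compound 4 (0.32 log units; beyond the scatter).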

Compound 4, half-maximal inhibitory concentration: 6.4 nM
Estimate against measurement, compound 4: 1.6-fold (0.20 log units) below; low and high end bracket the measured number.
By their numbers in this assay, from the lowest: compound 1; then compound 3; then compounds 4 and 2 (each within the scatter of the next).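

In this assay, methylsulfonyl in place of sulfamoylamino on a saturated chain carbon, two bonds along the chain from an amide-type nitrogen, gives a 3.4-fold higher number from compound 3 to compound 4 (0.53 log units; beyond the scatter), so this exchange is not silent, and the hydrogen-bond donors counted on the leaving group are absent from the entering one. The new side-chain also sets compound 4 apart from only one of the two hydroxy-bearing analogues: a 1.3-fold lower number from compound 2 to compound 4 (0.12 log units; within the scatter), whereas a 21-fold higher number from compound 1 to compound 4 (1.33 log units; beyond the scatter), which leaves the 1-hydroxyethyl side-chain of compound 1 with the lowest number of the four. Nothing measured here accounts for the size or direction of these steps.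

Methylsulfonylamino at the same place would separate the effect of the chain nitrogen from that of the outer amino group, since compound 3 and compound 4 differ in both. As far as these compounds go, how a carboxylic acid or a primary amine at the end of this chain, or a longer chain such as 3-(methylsulfonyl)propyl, would compare with compound 1 and compound 4 in this assay remains open.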